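The compounds below may be only part of what the source reports. "The series", "measured", "known", "first", "only" and "open" are said of these compounds alone.

Among the measured compounds shown here, compound 1 `CC(=O)N1CC2CC(C1)N2` gives 750 nM in an assay on CHO cells for agonist activity at Neuronal acetylcholine receptor; alpha3/alpha6/beta2/beta3 (Homo sapiens), read by FLIPR and calcium flux (on this read-out lower numbers stand for an effect already at smaller amounts and higher numbers for an effect only at larger amounts of compound), the highest of the two numbers measured so far. Its nearest neighbour is compound 2 `O=C([C@H]1C[C@H]1F)N1CC2CC(C1)N2`, which gives 62 nM; the two differ by a 12-fold lower number from compound 1 to compound 2 (1.08 log units; beyond the scatter).

Compound 3 `O=C([C@@H]1C[C@H]1F)N1CC2CC(C1)N2` has not been measured. Its change from compound 1 is 2-fluorocyclopropyl in place of methyl on a carbonyl carbon. For the measured compounds named here, compound 3 carries the same group as compound 2 but differs from it in the configuration at one of the two stereocentres, so the only step that bears on it is the one from compound 1 to compound 2, which was large. Compound 3 is therefore expected to give a lower number than compound 1, though the changed configuration leaves the size of the step uncertain, and the expected step is a 5.0-fold lower number from compound 1 to compound 3 (0.70 log units; beyond the scatter). For compound 3 the estimate is 150 nM, with a range from 40 nM to 600 nM.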

Compound 3, half-maximal effective concentration: 53 nM
Estimate against measurement, compound 3: 2.8-fold (0.45 log units) above, within the range that was stated.
By their numbers in this assay, from the lowest: compounds 3 and 2 (each within the scatter of the next); then compound 1.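

In this assay the second drawn form of the 2-fluorocyclopropyl group also brings a large step, a 14-fold lower number from compound 1 to compound 3 (1.15 log units; beyond the scatter), so the lower number on this carbonyl carbon is not tied to one form of the group. The change at the saturated ring carbon leaves the two fluorinated compounds within the scatter of each other, a 1.2-fold lower number from compound 2 to compound 3 (0.07 log units; within the scatter). This comparison of forms must be read with caution, because the drawn stereochemistry of the pair is not fully matched: the fact that one of compounds 2 and 3 is drawn with a defined configuration and the other without, at the place where they differ

From the compounds shown here alone, what a plain cyclopropyl or an ethyl would give in this place stays open, and with it how much of the step belongs to the fluorine and how much to the ring. Also open, going by these compounds, is whether an amine or a longer chain on the carbonyl carbon would give a similar number.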